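Ether chain in place of hydroxyalkyl on the aryl ether

The compounds below may be only part of what the source reports. "The series", "measured", "known", "first", "only" and "open" are said of these compounds alone.

Measured so far in an assay on membranes from lung (Cavia porcellus) for binding affinity to cysteinyl leukotriene receptor (Homo sapiens); on this read-out lower numbers stand for stronger inhibition and higher numbers for weaker inhibition:
compound 1 `CCCCCCCCCCCOc1ccccc1C(SCCC(=O)O)SCCC(=O)O` gives 287 nM
compound 2 `O=C(O)CCSC(SCCC(=O)O)c1ccccc1OCCCC1CCCCC1` gives 1010 nM
compound 3 `O=C(O)CCSC(SCCC(=O)O)c1ccccc1OCCCCCCCCCO` gives > 20000 nM

Compound 3 stands at the weak end of the three: its value in this assay is a limit, not a number, at the limit of > 20000 nM in this assay, at which 1 of the 3 values shown sits. The two measured steps that lead to it are both large: an at least 69-fold higher number from compound 1 to compound 3 (1.84 log units; beyond the scatter) and an at least 19-fold higher number from compound 2 to compound 3 (1.29 log units; beyond the scatter). The smaller step between the two alkyl compounds, a 3.5-fold higher number from compound 1 to compound 2 (0.55 log units; beyond the scatter), stays modest by comparison.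

Compound 4 `CCOCCOCCOCCOc1ccccc1C(SCCC(=O)O)SCCC(=O)O` differs from compound 3 by 2-(2-ethoxyethoxy)ethoxy in place of 7-hydroxyheptyl on a saturated chain carbon, two bonds along the chain from an oxygen on an aromatic ring. The change removes the terminal hydroxy of compound 3 and brings in a chain of ether oxygens without a hydroxy. The step from compound 1 to compound 3 bears most directly on this, since it was the hydroxy entering that carried the large loss; the step from compound 2 to compound 3 points the same way. Among the measured compounds shown here, compound 4 is therefore expected to give a lower number than the limit of compound 3, though no measured compound carries an ether chain, so the size is uncertain; an estimated step of an at least 5.0-fold lower number from compound 3 to compound 4 (0.69 log units; beyond the scatter) is taken. Compound 4 is expected at 4000 nM, in a range from 800 nM to 20000 nM.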

Compound 4, inhibition constant: > 20000 nM
Compound 4 gave a limit, no number; the forecaster's own chance of this, stated with the estimate: 35%; middle value at least 5.0-fold (0.69 log units) from the limit.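

In this assay compound 4 carries a limit and not a number, as does compound 3, so the step between them cannot be read: the limit of > 20000 nM in this assay, at which 2 of the 4 values shown sit.

Taking away the terminal hydroxy therefore does not bring back a readable value, and 2-(2-ethoxyethoxy)ethoxy, which has no hydroxy, still leaves compound 4 far from the two alkyl-type compounds, with an at least 69-fold higher number from compound 1 to compound 4 (1.84 log units; beyond the scatter) and an at least 19-fold higher number from compound 2 to compound 4 (1.29 log units; beyond the scatter). Among these four compounds, only the chains of carbon alone beyond the oxygen on the aromatic ring, in compound 1 and compound 2, give numbers, while both chains carrying further oxygen, in compound 3 and compound 4, end at the limit.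

On these data alone, how far compound 3 and compound 4 lie past that limit stays unknown, so the hydroxy-ended chain and the ether chain cannot be ranked against each other. Also open, as far as these compounds go, is whether a single ether oxygen set in an otherwise carbon chain, or a chain ending in a methoxy group or an amine, would give a readable value.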